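This account rests on a few compounds, and the source may have more. Where it says the series, first, only, none or still open, it means among the compounds named here.

Measured in a physicochemical assay for lipophilicity, at pH 7.4 (a higher number here means a more lipophilic compound, a lower number a more polar compound), so far
compound 1 (`O=C(Nc1ccc2[nH]ncc2n1)[C@H]1CCCN1C(=O)C1(c2ccc(F)cc2)CCC1`) gives 4.1
compound 2 (`O=C(Nc1ccc2[nH]ncc2n1)[C@H]1COCCN1C(=O)C1(c2ccc(Cl)cc2)CC(F)(F)C1`) gives 4.5
compound 3 (`O=C(Nc1ccc2[nH]c(=O)[nH]c2c1)[C@H]1CCCN1C(=O)C1(c2cccc(Cl)c2)CCCC1`) gives 4.4

Compound 3 at 4.4 lies within the scatter of both compound 2 and compound 1, so the numbers do not separate it from either. Next in the series is compound 4 (`O=C(Nc1ccc(O)cc1)[C@H]1CCCN1C(=O)C1(c2cccc(Cl)c2)CCCC1`), in which a 4-hydroxyphenyl group takes the place of the two-ring group on the amide-type nitrogen (a group of 7 heavy atoms (6 carbon, 1 oxygen; one six-membered aromatic ring of carbon only) in place of a group of 10 heavy atoms (7 carbon, 2 nitrogen, 1 oxygen; one five-membered aromatic ring with 2 hetero atoms, one six-membered aromatic ring of carbon only), on an amide-type nitrogen), with the rest of compound 3 unchanged. Within the data shown here, no measured pair isolates a change of this kind, so the expectation rests only on compound 3 at 4.4 as the starting point. In this assay a small downward step, not beyond the scatter, is expected. The estimated move a number 0.10 log units lower from compound 3 to compound 4 (within the scatter) therefore stays within what repeat measurements would show. For compound 4 the estimated value is 4.3 with an expected range from 3.9 to 4.7 in this measurement.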

Compound 4, distribution coefficient: 5.5
For compound 4 the middle estimate is 1.20 log units below the measured one; the whole stated range lies below it.
By their numbers in this assay, from the lowest: compounds 1, 3 and 2 (each within the scatter of the next, the first and the last beyond it); then compound 4.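

In this assay, exchanging the two-ring group on the amide-type nitrogen for 4-hydroxyphenyl gives a number 1.10 log units higher from compound 3 to compound 4 (beyond the scatter) with the rest of the molecule unchanged. Among these compounds, this is the first comparison confined to one place, and it shows that the group at this position can move the read-out beyond the scatter, which the earlier compounds, differing from one another in more than one place, could not assign to any single position. Nothing measured here bears on the origin of this step.

As far as these compounds go, it remains open whether the step follows the hydroxyl group, the loss of the two-ring group, or both, which a plain phenyl or a 4-methoxyphenyl group on the same nitrogen would help separate. From the compounds shown here alone, it is also open whether the same exchange gives a step of similar size on the cores of compound 1 and compound 2.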